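This account rests on a few compounds, and the source may have more. Where it says the series, first, only, none or still open, it means among the compounds named here.

Compound 1 `C=CCn1cc(C(N)=S)c2c(N)ncnc21` and compound 2 `COCCOCn1cc(C(N)=S)c2c(N)ncnc21` share one core and differ only in the group on the aromatic nitrogen of the five-membered ring. In a functional assay on KB cells (Homo sapiens) for cytotoxicity (on this read-out lower numbers stand for stronger inhibition and higher numbers for weaker inhibition), compound 1 gives 19000 nM, while compound 2 gives 183000 nM. That step, a 9.6-fold higher number from compound 1 to compound 2 (0.98 log units; beyond the scatter), shows a weaker inhibition once the larger chain is in place. Among the two numbers so far, compound 2 stands highest, with compound 1 as its only neighbour.

Compound 3 `NC(=S)c1c[nH]c2ncnc(N)c12` strips the chain away entirely: hydrogen in place of (2-methoxyethoxy)methyl on an aromatic nitrogen. Going by the values given here, the one measured step that touches the same place is the step from compound 1 to compound 2, where swapping a small group for a longer chain raised the number beyond the scatter. Reading that step backwards, a shorter group, and here no group at all, is expected to give a lower number, though whether a bare hydrogen behaves like the small vinyl-bearing chain of compound 1 is unknown. For compound 3 the expected step is a 6.1-fold lower number from compound 2 to compound 3 (0.79 log units; beyond the scatter). Compound 3 is therefore estimated at 30000 nM, within a range from 8000 nM to 150000 nM.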

Compound 3, half-maximal inhibitory concentration: 25000 nM
For compound 3 the middle estimate is 1.2-fold (0.08 log units) above the measured one, within the range that was stated.
By their numbers in this assay, from the lowest: compounds 1 and 3 (each within the scatter of the next); then compound 2.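

Removing the (2-methoxyethoxy)methyl group from the aromatic nitrogen gives a 7.3-fold lower number from compound 2 to compound 3 (0.86 log units; beyond the scatter) in this assay and thus shows that this position needs no group at all to reach the level seen with the allyl group. The comparison with the allyl compound, a 1.3-fold higher number from compound 1 to compound 3 (0.12 log units; within the scatter) and so within the scatter, means that allyl and hydrogen cannot be told apart here, leaving the (2-methoxyethoxy)methyl group as the only one of the three that stands apart, with the weaker inhibition. Nothing available explains why this chain weakens inhibition while the allyl group and the bare hydrogen do not.

Going by these compounds alone, with only three groups at this nitrogen, it remains open whether the length of the chain or the oxygen atoms within it go with the weaker inhibition, and a plain hexyl chain, which has no oxygen, would help separate the two. Also open, as far as these compounds go, is how this position responds to groups of other kinds, such as a benzyl group, a chain ending in an amine or one ending in a carboxylic acid.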